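Three Inactive Analogues and a Fourth Awaiting Measurement

The source may report more compounds than this note shows. Statements on the series, on what has been measured and on what is new or still open speak of the compounds shown alone.

Compound 1 `Nc1ccn(C[C@H](O)[C@H]2OC(=O)C(OCc3ccccc3)=C2OCc2ccccc2)c(=O)n1`: in a functional assay on SW-620 cells (Homo sapiens) for inhibition, read by MTT assay, with a stated time of 72 h (on this read-out higher numbers stand for weaker inhibition and lower numbers for stronger inhibition), compound 1 reaches only the limit > 100000 nM.
Compound 2 `Nc1ccn(CCC2(N)OC(=O)C(OCc3ccccc3)=C2OCc2ccccc2)c(=O)n1`: in this assay compound 2 reaches only the limit > 100000 nM.
Compound 3 `NC1(CCn2c(=O)[nH]c(=O)[nH]c2=O)OC(=O)C(OCc2ccccc2)=C1OCc1ccccc1`: in this assay compound 3 reaches only the limit > 100000 nM.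

None of the three measured compounds gives a number in this assay; each sits at the limit, so the limit of > 100000 nM in this assay, at which 3 of the 3 values shown sit, is all the evidence the series offers. The step from compound 2 to compound 3, a step that the two limits leave unreadable from compound 2 to compound 3, is therefore not readable; the change behind it is a group of 9 heavy atoms (3 carbon, 3 nitrogen, 3 oxygen; one six-membered aromatic ring with 3 hetero atoms) in place of a group of 8 heavy atoms (4 carbon, 3 nitrogen, 1 oxygen; one six-membered aromatic ring with 2 hetero atoms), on a saturated chain carbon, two bonds along the chain from a saturated ring carbon. How the core of compound 1 differs from that of compound 2 is not broken down here.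

Compound 4 `O=C1O[C@H]([C@@H](O)Cn2c(=O)[nH]c(=O)[nH]c2=O)C(OCc2ccccc2)=C1OCc1ccccc1` is not yet measured. Going by the values given here, it arises from compound 1 by a group of 9 heavy atoms (3 carbon, 3 nitrogen, 3 oxygen; one six-membered aromatic ring with 3 hetero atoms) in place of a group of 8 heavy atoms (4 carbon, 3 nitrogen, 1 oxygen; one six-membered aromatic ring with 2 hetero atoms), on a saturated chain carbon, two bonds along the chain from an oxygen on a saturated carbon and a saturated ring carbon, the same kind of change as the one from compound 2 to compound 3, though the place differs: in compound 1 the chain carbon is two bonds along the chain from an oxygen on a saturated carbon and a saturated ring carbon, whereas in compound 2 it is two bonds along the chain from a saturated ring carbon only. Because compound 1 sits at the limit of > 100000 nM in this assay, at which 3 of the 3 values shown sit, and the same kind of change left compound 3 at the limit of > 100000 nM in this assay, at which 3 of the 3 values shown sit, the step from compound 1 to compound 4 is expected to be unreadable as well, a step that the limit leaves unreadable from compound 1 to compound 4. Compound 4 is therefore estimated at 200000 nM, most likely again reported only as a limit, with a range from 100000 nM to 1000000 nM.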

Compound 4, half-maximal inhibitory concentration: > 100000 nM
Compound 4: no number, only a limit (the forecaster's own chance of this, stated with the estimate: 90%); the middle value does not contradict the limit.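

Compound 1 and compound 4 each give only a limit, not a number, so no new step can be read between them, and the series still rests on a single observation: the limit of > 100000 nM in this assay, at which 4 of the 4 values shown sit.

The compounds shown leave open how large any difference among these four compounds really is, and whether any change to the shared core or its chain would give a measurable number in this assay.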